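Hydrogen for Fluoro: What to Expect of Compound 4

A few compounds are considered here, and "the series" means these few. Any claim that something is new, unique, unknown or untested is made for them only; others in the source may bear on it.

Compound 1 `Fc1ccc2nc(NCCCCN3CCN(c4cccc(Cl)c4Cl)CC3)nc(NCc3ccco3)c2c1` gives 95.5% in a functional assay on DU-145 cells (Homo sapiens) for cytotoxicity, read by MTT assay, with a stated time of 2 days, tested at 10 uM; on this read-out lower numbers stand for less inhibition and higher numbers for more inhibition at the one concentration tested (going by the name of the read-out).
Compound 2 `Clc1cccc(N2CCN(CCCCNc3nc(NCc4ccco4)c4ccccc4n3)CC2)c1Cl` gives 94.3% in this assay.
Compound 3 `CCN(CC)CCNc1nc(NCc2ccco2)c2cc(F)ccc2n1` gives 26.6% in this assay.

Compound 1 and compound 2 differ in a single place: hydrogen in place of fluoro on an aromatic carbon. In this assay this change made a step of a number 1.2 percentage points lower from compound 1 to compound 2 (within the scatter), so the two compounds are read as equivalent. Compound 3 stands well apart from both; its value lies beyond the scatter below compound 2 and below compound 1. How the core of compound 3 differs from the core of compound 1 is not broken down here, since the two differ in more than one place.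

Compound 4 `CCN(CC)CCNc1nc(NCc2ccco2)c2ccccc2n1` has not yet been measured in this assay. It differs from compound 3 by hydrogen in place of fluoro on an aromatic carbon. The place line for this change reads the same, word for word, as for the change from compound 1 to compound 2, so it is the same change made on a different core.

Because that change gave a number 1.2 percentage points lower from compound 1 to compound 2 (within the scatter), a step within the scatter, compound 4 is expected to stay close to compound 3. The expected step is estimated as a number 1.6 percentage points lower from compound 3 to compound 4 (within the scatter). Compound 4 is therefore estimated to give about 25% in this assay. The expected range for compound 4 runs from 10% to 42%. This rests on one measured pair only, and a different core could behave otherwise.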

Compound 4, a percentage reported as inhibition, at one concentration (the size of the read-out at that concentration, not a potency): 28.5%
Estimate against measurement, compound 4: 3.5 percentage points below; the measured number falls inside the stated range.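

Hydrogen in place of fluoro made a step of a number 1.9 percentage points higher from compound 3 to compound 4 (within the scatter) in this assay, so the change left no readable mark on this second core, just as it left none on the core of compound 1. Set side by side, the two steps do not differ: the same change on two cores in this assay, a number 1.2 percentage points lower (within the scatter) from compound 1 to compound 2 and a number 1.9 percentage points higher (within the scatter) from compound 3 to compound 4, 3.1 percentage points apart, within the scatter of two such steps. This shows that, across these two pairs, the change carried from one core to the other without a step beyond the scatter, but it does not show that fluoro at this aromatic carbon is without consequence in general, as it rests on two pairs, one cell line and a single concentration, which gives no potency.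

The compounds shown leave open whether a different group on the same aromatic carbon, such as methoxy or trifluoromethyl, would leave the number as unmoved as hydrogen in place of fluoro did on these two cores. They also leave open whether the change would stay within the scatter on a core carrying a carboxylic acid or a longer chain.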